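Replacing the methylsulfanyl group of compound 3

The source may report more compounds than this note shows. Statements on the series, on what has been measured and on what is new or still open speak of the compounds shown alone.

In a functional assay on the whole organism with Rattus norvegicus as the target (on this read-out higher numbers stand for an effect only at larger amounts of compound and lower numbers for an effect already at smaller amounts), compound 3 (`CSCCn1c(=N)sc2cc(OC(F)(F)F)ccc21`) gives 1 mg/kg as the lowest number shown. Compound 1 (`N=c1sc2cc(OC(F)(F)F)ccc2n1CCS(N)(=O)=O`) gives 6 mg/kg and so stands higher. Compound 2 (`N=c1sc2cc(OC(F)(F)F)ccc2n1CCS(=O)(=O)O`) reads > 10 mg/kg as a limit of the assay. Compound 4 (`N=c1sc2cc(OC(F)(F)F)ccc2n1CC[S+]([O-])c1ccccc1`) differs from compound 3 in one place (a group of 8 heavy atoms (6 carbon, 1 oxygen, 1 sulfur; one six-membered aromatic ring of carbon only) in place of a group of 2 heavy atoms (1 carbon, 1 sulfur; no ring), on a saturated chain carbon, two bonds along the chain from an aromatic nitrogen). Among the compounds with values here, two measured steps bear on this place: a 6.0-fold lower number from compound 1 to compound 3 (0.78 log units; beyond the scatter) and an at least 10-fold lower number from compound 2 to compound 3 (1.00 log units; beyond the scatter) both lie beyond the scatter and both arrive at methylsulfanyl, which points to a higher number once that group leaves. Neither earlier group holds a ring, so the guide is loose. A rise of modest size is expected (a 3.0-fold higher number from compound 3 to compound 4 (0.48 log units; beyond the scatter)). For compound 4 the estimated value in this assay is 3 mg/kg with 1 mg/kg to 10 mg/kg as the expected range.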

Compound 4, dose for half-maximal effect: 4.2 mg/kg
The estimate for compound 4 lay 1.4-fold (0.15 log units) below the measured number; low and high end bracket the measured number.
By their numbers in this assay, from the lowest: compound 3; then compounds 4 and 1 (each within the scatter of the next). At a limit, above all of these: compound 2.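

In this assay, a group holding a six-membered aromatic ring at this chain carbon does not match methylsulfanyl, with a 4.2-fold higher number from compound 3 to compound 4 (0.62 log units; beyond the scatter). It reads level with the sulfamoyl group, with a 1.4-fold lower number from compound 1 to compound 4 (0.15 log units; within the scatter), so these two quite different groups cannot be told apart here. Against the sulfo group the step, an at least 2.3-fold lower number from compound 2 to compound 4 (0.37 log units; beyond the scatter), is only a floor, as compound 2 stands at a limit: the limit of > 10 mg/kg in this assay, at which 1 of the 4 values shown sits.

The compounds shown carry the ring and the oxygen on sulfur only together, so which of the two matters stays open. On these data alone, how an amine or a carboxylic acid at this place would read also stays open.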